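The source may report more compounds than this note shows. Statements on the series, on what has been measured and on what is new or still open speak of the compounds shown alone.

In an ADME assay on NBT-T2 cells (Rattus norvegicus) for cytotoxicity, read by MTT assay (on this read-out lower numbers stand for stronger inhibition and higher numbers for weaker inhibition), compound 1 (`COc1c(Br)cc(Br)cc1Oc1c(O)c(Br)c(Br)c(Br)c1Br`) gives > 15 ug/mL, which is a limit and not a number. Compound 2 (`Oc1c(Br)cc(Br)cc1Oc1c(Br)ccc(Br)c1O`) gives > 15 ug/mL, also a limit. Compound 3 (`Oc1ccc(Br)cc1Oc1c(O)c(Br)cc(Br)c1Br`) gives > 15 ug/mL, again a limit. The picture so far is therefore (the limit of > 15 ug/mL in this assay, at which 3 of the 3 values shown sit). Compound 4 (`COc1c(Br)cc(Br)cc1Oc1c(O)cc(Br)c(Br)c1Br`) departs from compound 1 by a single change, hydrogen in place of bromo on an aromatic carbon. Among the compounds with values here, no pair of measured compounds shows this change, and the limits give no size for it. The expected a number no higher from compound 1 to compound 4 (the limit leaves the size open) is no larger than the usual scatter, with no direction favoured. This expectation rests on compound 1 and its limit of > 15 ug/mL. For compound 4 the estimated value is 15 ug/mL, with an expected range of 7 ug/mL to 30 ug/mL.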

Compound 4, half-maximal inhibitory concentration: 2.8 ug/mL
For compound 4 the middle estimate is 5.4-fold (0.73 log units) above the measured one, outside the stated range (below it).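

In this assay, hydrogen in place of bromo on this aromatic carbon, ortho to a hydroxy group and to a bromo group, brings an at least 5.3-fold lower number from compound 1 to compound 4 (0.72 log units; beyond the scatter). The position therefore responds to this single change, and the loss of one bromo is enough to produce a measurable number. Compound 4 is the only compound shown that gives a number and not a limit: the limit of > 15 ug/mL in this assay, at which 3 of the 4 values shown sit.

As far as these compounds go, whether the same change on other aromatic carbons of the core has a similar effect remains open. So does the effect of an amine, a carboxylic acid or a longer chain at this position.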